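Ethoxy Imine in Place of a Dinitrophenyl Imine

This account rests on a few compounds, and the source may have more. Where it says the series, first, only, none or still open, it means among the compounds named here.

Compound 1 `N#CC1=C(N)N(c2ccc(S(N)(=O)=O)cc2)C2=C(C(=O)CCC2)C1c1ccc(Cl)cc1Cl` gives 50% in a functional assay on Ehrlich cells (Mus musculus) for cytotoxicity, read by trypan blue exclusion, with a stated time of 2 h, tested at 25 ug/mL; a higher number here means a stronger effect of the compound at the concentration tested, a lower number a weaker effect. Compound 2 `N#CC1=C(/N=C/c2ccc([N+](=O)[O-])cc2[N+](=O)[O-])N(c2ccc(S(N)(=O)=O)cc2)C2=C(C(=O)CCC2)C1c1ccc(Cl)cc1Cl` gives 20% in this assay, the lower of the two numbers, and its gap to compound 1 lies beyond the scatter. Compound 3 `CCO/C=N/C1=C(C#N)C(c2ccc(Cl)cc2Cl)C2=C(CCCC2=O)N1c1ccc(S(N)(=O)=O)cc1` differs from compound 2 in one place: ethoxy in place of 2,4-dinitrophenyl on a carbon with a double bond to nitrogen. For the measured compounds named here, no step between two measured compounds matches this change, so the expectation rests on compound 2 at 20% alone. Compound 3 is expected to give 30%, within 10% to 55%. The step of a number 10 percentage points higher from compound 2 to compound 3 (within the scatter) is expected to be a modest rise, perhaps not beyond the scatter.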

Compound 3, a percentage reported as activity, at one concentration (the size of the read-out at that concentration, not a potency): 30%
Compound 3: the middle estimate sits on the measured number at the digits printed, within the range that was stated.
By their numbers in this assay, from the lowest: compounds 2 and 3 (each within the scatter of the next); then compound 1.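

Ethoxy in place of 2,4-dinitrophenyl on a carbon with a double bond to nitrogen gives a number 10 percentage points higher from compound 2 to compound 3 (within the scatter) in this assay so this large change at the position does not separate the two imines. Set against the single nitrogen atom on the double-bonded ring carbon, the ethoxy imine still gives a number 20 percentage points lower from compound 1 to compound 3 (beyond the scatter) so the lower read-out does not require the dinitrophenyl ring. No evidence here explains either step.

As far as these compounds go, whether a longer alkoxy chain, an unsubstituted phenyl or a dimethylamino group on this carbon would read differently remains open.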